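Purine benzyl series: amino-for-chloro step, positional isomer

This account rests on a few compounds, and the source may have more. Where it says the series, first, only, none or still open, it means among the compounds named here.

Working notes. Compound 1 `ClCc1ccccc1Cn1cnc2c(Cl)nc(Cl)nc21` in a functional assay on CCRF-CEM cells (Homo sapiens) for cytotoxicity, read by sulforhodamine B assay, with a stated time of 48 h (on this read-out lower numbers stand for stronger inhibition of growth and higher numbers for weaker inhibition of growth), gives 90 nM. Compound 2 `ClCc1cccc(Cn2cnc3c(Cl)nc(Cl)nc32)c1` is built from the same atoms joined differently; the difference between the two cores is not broken down here. In this assay compound 2 reaches only a limit of the assay, > 100000 nM, and no number. Compound 3 `Nc1nc(Cl)c2ncn(Cc3ccccc3CCl)c2n1` differs from compound 1 by amino in place of chloro on an aromatic carbon. In this assay compound 3 likewise shows only a limit, > 100000 nM. The measured step is an at least 1100-fold higher number from compound 1 to compound 3 (3.04 log units; beyond the scatter); its true size is open because the limit of > 100000 nM in this assay, at which 2 of the 3 values shown sit, is where the end point sits.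

Compound 4 `Nc1nc(Cl)c2ncn(Cc3cccc(CCl)c3)c2n1` is not yet measured. It differs from compound 2 by amino in place of chloro on an aromatic carbon, the same change as from compound 1 to compound 3, at a place described in the same words. In this assay compound 4 is expected to give about 150000 nM, likely between 60000 nM and 500000 nM. The expected step that the limit leaves unreadable from compound 2 to compound 4 is essentially flat, since compound 2 already sits at a limit. A further move upward, as in the step of an at least 1100-fold higher number from compound 1 to compound 3 (3.04 log units; beyond the scatter), would stay unseen at that limit.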

Compound 4, concentration for total growth inhibition: > 100000 nM
Compound 4 gave a limit, no number; the forecaster's own chance of this, stated with the estimate: 90%; the middle value lies beyond the limit too.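

No new step can be read between compound 2 and compound 4, because both values are limits and not numbers: the limit of > 100000 nM in this assay, at which 3 of the 4 values shown sit.

The compounds shown leave open whether amino in place of chloro on an aromatic carbon changes the read-out at all when going from compound 2 to compound 4.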